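The source may report more compounds than this note shows. Statements on the series, on what has been measured and on what is new or still open speak of the compounds shown alone.

compound 1 `OC[C@H]1O[C@@H](n2cnc3c(NCc4ccccc4F)ncnc32)[C@H](O)[C@@H]1O`: > 166000 nM
compound 2 `Cc1cccc(CNc2ncnc3c2ncn3[C@@H]2O[C@H](CO)[C@@H](O)[C@H]2O)c1`: > 166000 nM

In a functional assay on HOS cells (Homo sapiens) for antiproliferative activity, with a stated time of 72 h (a higher number here means a weaker inhibitor, a lower number a stronger inhibitor), compound 1 gives > 166000 nM, which is a limit of the assay and not a number. Compound 2 in this assay likewise gives > 166000 nM, again a limit rather than a number. The step that the two limits leave unreadable from compound 1 to compound 2 cannot be read because of the limit of > 166000 nM in this assay, at which 2 of the 2 values shown sit. For the measured compounds named here, compound 2 thus stands at the limit, and the one other value in hand is a limit as well. Compound 3, `OC[C@H]1O[C@@H](n2cnc3c(NCc4ccc(F)c(Cl)c4)ncnc32)[C@H](O)[C@@H]1O`, is not yet measured; it differs from compound 2 by 3-chloro-4-fluorophenyl in place of 3-methylphenyl on a saturated chain carbon bound to a nitrogen on an aromatic ring. Going by the values given here, the single measured step touches the same position, but its size is not readable, so no direction can be taken from it. With both known values at the limit, compound 3 is expected to remain near that limit, and the step that the limit leaves unreadable from compound 2 to compound 3 is estimated as nothing that could be read. The estimate for compound 3 in this assay is 200000 nM, with a range of 40000 nM to 1000000 nM.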

Compound 3, half-maximal inhibitory concentration: > 166000 nM
Compound 3 was reported as a limit; the forecaster's own chance of this, stated with the estimate: 75%; the middle value is on the limit's open side.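

No step among compound 1, compound 2 and compound 3 can be read in this assay, because all three values are limits and not numbers: the limit of > 166000 nM in this assay, at which 3 of the 3 values shown sit.

The compounds shown leave open how the 2-fluorophenyl, 3-methylphenyl and 3-chloro-4-fluorophenyl groups rank against one another on the shared core.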